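The source may hold more compounds than are shown below. What is called first, only, known or untested is meant among the compounds shown, and "the series" means these compounds.

The starting point is compound 1, `C[C@@H](C(=O)O)c1nn(Cc2cn3cc(OCC4CC4)c(Cl)cc3n2)c2ccccc2c1=O`. Measured in a functional assay on HFL1 cells for antagonist activity at sphingosine 1-phosphate receptor 2 (Homo sapiens), read by ELISA, with a stated time of 24 h, in the presence of a further agent that is not named here (a higher number here means a weaker inhibitor, a lower number a stronger inhibitor), compound 1 gives 3180 nM, the highest of the three numbers available. Two companions sharing the same core sit lower: compound 2, `O=C(O)Cn1nc(Cc2cn3cc(OCC4CC4)c(Cl)cc3n2)c2ccccc2c1=O`, which in this assay gives 275 nM, and compound 3, `CC(C(=O)O)c1nn(Cc2cn3cc(OCC4CC4)c(C(F)(F)F)cc3n2)c2ccccc2c1=O`, which in this assay gives 56 nM. Both gaps from compound 1 lie beyond the usual scatter of repeated measurements, so compound 1 is the weakest inhibitor of the three.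

The next compound is compound 4, `CCC(C(=O)O)c1nn(Cc2cn3cc(OCC4CC4)c(Cl)cc3n2)c2ccccc2c1=O`. It differs from compound 1 in a single place: 1-carboxypropyl in place of 1-carboxyethyl on an aromatic carbon. Within the data shown here, the single defined stereocentre of compound 1 is no longer specified in compound 4. Among the measured compounds shown here, no measured pair shows this exact change, so any expectation rests only on the spread seen across the three compounds, which is wide. A moderate move toward a stronger inhibitor, rather than none at all, is expected, with considerable uncertainty. The change is estimated to shift the number by a 2.7-fold lower number from compound 1 to compound 4 (0.42 log units; beyond the scatter). Compound 4 is expected to give 1200 nM in this assay, within a range from 250 nM to 5000 nM.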

Compound 4, half-maximal inhibitory concentration: 25 nM
Compound 4: the middle estimate sits 48-fold (1.68 log units) above what was measured, outside the stated range (below it).
By their numbers in this assay, from the lowest: compound 4; then compound 3; then compound 2; then compound 1.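

In this assay, placing 1-carboxypropyl instead of 1-carboxyethyl on the aromatic carbon next to the ring nitrogen gives a 130-fold lower number from compound 1 to compound 4 (2.10 log units; beyond the scatter), so a small change to this acid-bearing side chain can strongly alter inhibition. The step also carries a second difference: compound 1 has one defined stereocentre, whereas none is specified in compound 4. No measurement available here explains the size of this step.

From the compounds shown here alone, it remains open how much of the gain comes from the chain and how much from the stereochemical difference, which separate mirror-image forms of compound 4 could help resolve. It is also unclear whether a longer chain, such as 1-carboxybutyl, or a ring such as cyclopropyl at this position would keep the stronger inhibition.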